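This account rests on a few compounds, and the source may have more. Where it says the series, first, only, none or still open, it means among the compounds named here.

Measured so far:
compound 1, `CC1=C(/C=C/C(=O)/C=C/c2ccccc2)C(C)(C)CCC1`, in a functional assay on Hep cells (Homo sapiens) for cytotoxicity, read by sulforhodamine B assay, with a stated time of 48 h (on this read-out lower numbers stand for stronger inhibition and higher numbers for weaker inhibition), gives 62200 nM.
compound 2, `COc1ccc(/C=C/C(=O)/C=C/C2=C(C)CCCC2(C)C)cc1`, in this assay reaches only a limit of the assay, > 100000 nM.
compound 3, `CC1=C(/C=C/C(=O)/C=C/C=C/c2ccccc2)C(C)(C)CCC1`, in this assay likewise reaches only a limit of the assay, > 100000 nM.

Compound 2 differs from compound 1 in one place: methoxy in place of hydrogen on an aromatic carbon. This change gave an at least 1.6-fold higher number from compound 1 to compound 2 (0.20 log units; that floor lies within the scatter); the value of compound 2 is a limit, so the true size of the step is not known, because of the limit of > 100000 nM in this assay, at which 2 of the 3 values shown sit.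

Compound 3 and compound 1 share no single-point difference; how their two cores differ is not broken down here. Compound 1 gives a number, whereas compound 3 gives only a limit, so the two cannot be ranked against each other.

Compound 4, `COc1ccccc1/C=C/C=C/C(=O)/C=C/C1=C(C)CCCC1(C)C`, has not yet been tested. It stands to compound 3 as compound 2 stands to compound 1: methoxy in place of hydrogen on an aromatic carbon. The place is not identical, since in compound 2 the methoxy sits para to a large group and in compound 4 it sits ortho to a large group, so this is the same kind of change rather than the same change.

Compound 4 is expected to move by a step that the limit leaves unreadable from compound 3 to compound 4, a step that rests on the measured step of an at least 1.6-fold higher number from compound 1 to compound 2 (0.20 log units; that floor lies within the scatter), where the same kind of change gave no numerical value, and on the starting point of compound 3 already being a limit. For compound 4 the estimate is 150000 nM, within 60000 nM to 400000 nM, most likely reported again as a limit.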

Compound 4, half-maximal inhibitory concentration: 65300 nM
Estimate against measurement, compound 4: 2.3-fold (0.36 log units) above; the measured number falls inside the stated range.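

In this assay, methoxy in place of hydrogen on an aromatic carbon gave an at least 1.5-fold lower number from compound 3 to compound 4 (0.18 log units; that floor lies within the scatter), and this step is only a floor that lies within the usual scatter of the measurement. Set beside the earlier step, the same kind of change gives no firm answer on whether its effect carries from one core to the other: the same change on two cores in this assay, an at least 1.6-fold higher number (0.20 log units; that floor lies within the scatter) from compound 1 to compound 2 and an at least 1.5-fold lower number (0.18 log units; that floor lies within the scatter) from compound 3 to compound 4; the limit leaves it open whether they differ The result does not show that methoxy strengthens or weakens inhibition in this series, and it gives the true size of neither step, since each of them has a limit at one end and the methoxy does not sit in the same place on the two cores: the limit of > 100000 nM in this assay, at which 2 of the 4 values shown sit.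

The compounds shown leave open whether methoxy placed identically on both cores would move the read-out in this assay by a similar amount, which would be a more direct test of carrying the change across. They also leave open how other groups on the same aromatic ring, such as a hydroxyl, a chlorine or an amine, would read in that assay, and whether any of them would give a number rather than a limit.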